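Lengthening the acyl chain from acetyl to propanoyl

This account rests on a few compounds, and the source may have more. Where it says the series, first, only, none or still open, it means among the compounds named here.

Measured so far:
Compound 1 `COc1cc(C(=O)O)ccc1OCCCCOc1ccc(C(=O)C(C)C)c(O)c1C` gives 73.1%
Compound 2 `COc1cc(C(=O)O)ccc1OCCCCOc1ccc(C(C)=O)c(O)c1C` gives 86.3%

In an assay on HEK293 cells for positive allosteric modulation of metabotropic glutamate receptor 2 (Rattus norvegicus), read by thallium flux, with a stated time of 2.5 min (on this read-out higher numbers stand for larger maximal responses and lower numbers for smaller maximal responses), compound 2 stands highest of the two numbers shown. Going by the values given here, its only neighbour is compound 1, and the step of a number 13.2 percentage points higher from compound 1 to compound 2 (beyond the scatter) is a modest rise that lies beyond the usual scatter, so the smaller acyl group on the carbonyl carbon goes with the larger maximal response here.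

Compound 3 `CCC(=O)c1ccc(OCCCCOc2ccc(C(=O)O)cc2OC)c(C)c1O` is the next step in the same part of the molecule. It differs from compound 2 by methyl in place of hydrogen on a saturated chain carbon bound to a carbonyl carbon.

Among the compounds with values here, the one measured step that bears on this change is the one from compound 1 to compound 2: shrinking the group on the carbonyl carbon raised the maximal response modestly. Compound 3 moves part of the way back toward compound 1, since a propanoyl group is larger than acetyl yet smaller than the isopropyl ketone of compound 1. A modest fall, smaller than the measured step, is therefore expected, as a number 7.3 percentage points lower from compound 2 to compound 3 (within the scatter). For compound 3 the expected value in this assay is 79%, with a range from 66% to 92%.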

Compound 3, largest response reached (reported as percent of maximum), in percent of the reference or control that the assay uses: 86.5%
Beside the measured number, compound 3's estimate is 7.5 percentage points below it; the range from low to high includes it.
By their numbers in this assay, from the lowest: compound 1; then compounds 2 and 3 (each within the scatter of the next).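

In this assay, adding one methyl to the acetyl group of compound 2 to make the propanoyl group of compound 3 leaves the maximal response unchanged within the usual scatter (a number 0.2 percentage points higher from compound 2 to compound 3 (within the scatter)). The earlier drop with the isopropyl ketone therefore does not simply continue down through every added carbon: acetyl and propanoyl sit together, and among these three compounds only the isopropyl ketone of compound 1 stands apart (a number 13.4 percentage points higher from compound 1 to compound 3 (beyond the scatter)). This position thus accepts the change from methyl to ethyl on the carbonyl carbon without a measurable loss, and the lower response appears only with the isopropyl group.

Nothing available here explains why the isopropyl ketone of compound 1 gives the lower response. These three compounds leave open whether branching or overall size sets the difference, a question that a straight butanoyl chain or a cyclopropyl group on the carbonyl carbon could help to separate.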